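The source may hold more compounds than are shown below. What is called first, only, known or untested is meant among the compounds shown, and "the series" means these compounds.

Measured compounds in the series:
- compound 1, `O=c1[nH]c(=O)n([C@H]2C[C@H](O)[C@@H](CO)O2)cc1CF`: 11 uM
- compound 2, `O=c1[nH]c(=O)n([C@H]2C[C@H](O)[C@@H](CO)O2)cc1C(F)F`: 0.063 uM

Going by the values given here, compound 2 holds the lowest number of the two in an assay on L1210 cells for inhibition of Thymidylate synthase (Mus musculus); a higher number here means a weaker inhibitor, a lower number a stronger inhibitor; its nearest neighbour is compound 1, and the single step of a 170-fold lower number from compound 1 to compound 2 (2.24 log units; beyond the scatter) is a large one.

Compound 3, `O=c1[nH]c(=O)n([C@H]2C[C@H](O)[C@@H](CO)O2)cc1CO`, is not yet measured. Its change from compound 2 is hydroxymethyl in place of difluoromethyl on an aromatic carbon. Among the compounds with values here, no measured pair exchanges the difluoromethyl for a hydroxymethyl, so the only step that bears on it is the one from compound 1 to compound 2, which shows that the group at this position moves the number strongly. Taking that step out again, and with the entering group bringing a hydrogen-bond donor and acceptor that neither measured compound carries, compound 3 is expected to give a much higher number in this assay, roughly a 320-fold higher number from compound 2 to compound 3 (2.50 log units; beyond the scatter). The estimate for compound 3 is 20 uM, with a range from 2 uM to 200 uM.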

Compound 3, concentration for 50% inhibition: > 1000 uM
Compound 3: a limit, no number; the forecaster's own chance of this, stated with the estimate: 25%; middle value at least 50-fold (1.69 log units) from the limit.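

Compound 3 gives no number in this assay, only a limit: the limit of > 1000 uM in this assay, at which 1 of the 3 values shown sits.

On the aromatic carbon, hydroxymethyl in place of difluoromethyl gives an at least 15000-fold higher number from compound 2 to compound 3 (4.20 log units; beyond the scatter), and hydroxy in place of fluoro on the same chain carbon gives an at least 90-fold higher number from compound 1 to compound 3 (1.95 log units; beyond the scatter). Going by these compounds alone, the earlier pair showed only that a second fluorine lowers the number, whereas the three compounds now rank in one order, with difluoromethyl lowest, fluoromethyl in the middle and hydroxymethyl highest, and even the single fluorine of compound 1 is far better here than the hydroxy of compound 3.

From the compounds shown here alone, whether the high reading of compound 3 belongs to the entering hydroxy or simply to the loss of fluorine stays open, and a plain methyl at this position would separate the two. A trifluoromethyl would show whether the fall in the number continues past difluoromethyl.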